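The compounds below may be only part of what the source reports. "The series", "measured", "known", "first", "only" and "open" are said of these compounds alone.

Measured in a functional assay on MCF7 cells (Homo sapiens) for inhibition, read by MTT assay, with a stated time of 5 days; on this read-out higher numbers stand for weaker inhibition and lower numbers for stronger inhibition:
- Compound 1 `Cc1cc(Nc2nc(NCc3ccccc3F)nc3[nH]ncc23)n[nH]1`: 2310 nM
- Compound 2 `Cc1cc(Nc2nc(NCc3ccc(F)cc3F)nc3[nH]ncc23)n[nH]1`: 670 nM

Of these two compounds, compound 2 holds the lower number, 670 nM, and so shows the stronger inhibition. The next molecule is compound 3 `COc1ccc(CNc2nc(Nc3cc(C)[nH]n3)c3cn[nH]c3n2)cc1`, which keeps the shared core but carries a different ring. The change is 4-methoxyphenyl in place of 2,4-difluorophenyl on a saturated chain carbon bound to a nitrogen on an aromatic ring.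

Within the data shown here, only one measured step bears on this. It is a 3.4-fold lower number from compound 1 to compound 2 (0.54 log units; beyond the scatter), where fluoro replaced hydrogen on an aromatic carbon. That step is modest and helps only indirectly. Among the measured compounds shown here, compound 3 carries no fluoro at all, and no compound with a 4-methoxyphenyl group has been measured, so the effect of the methoxy group in this assay is unknown. The most reasonable expectation is that part of the gain seen with compound 2 is lost, moving the number back towards that of compound 1 at 2310 nM. The expected change is a 2.2-fold higher number from compound 2 to compound 3 (0.35 log units; beyond the scatter), a modest step towards weaker inhibition. For compound 3 the estimated value is 1500 nM, with an expected range from 450 nM to 4500 nM.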

Compound 3, half-maximal inhibitory concentration: 3320 nM
Estimate against measurement, compound 3: 2.2-fold (0.35 log units) below; the range from low to high includes it.
By their numbers in this assay, from the lowest: compound 2; then compounds 1 and 3 (each within the scatter of the next).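

In this assay the exchange of 2,4-difluorophenyl for 4-methoxyphenyl on the saturated chain carbon gives a 5.0-fold higher number from compound 2 to compound 3 (0.70 log units; beyond the scatter) and so loses the stronger inhibition of compound 2. This shows that the read-out at this position depends on what the aromatic ring carries, not merely on a ring being present. The exchange of 2-fluorophenyl for 4-methoxyphenyl gives a 1.4-fold higher number from compound 1 to compound 3 (0.16 log units; within the scatter) and leaves compound 1 and compound 3 indistinguishable in this assay, even though their rings carry different groups, and no supporting measurement accounts for either result.

The three compounds do not separate the contribution of each fluoro from that of the methoxy, and a 4-fluorophenyl group would help to show whether the fluoro at that ring position can by itself account for the difference between compound 1 and compound 2. From the compounds shown here alone, whether a 4-chlorophenyl group, a 4-hydroxyphenyl group or a 4-aminophenyl group would match compound 2 or fall back to the level of compound 1 and compound 3 also remains open.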